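Pyridin-2-yl in place of 3-fluorophenyl

The compounds below may be only part of what the source reports. "The series", "measured", "known", "first", "only" and "open" are said of these compounds alone.

In a functional assay on HepG2 cells (Homo sapiens) for antiproliferative activity, read by MTT assay, with a stated time of 48 h (on this read-out higher numbers stand for weaker inhibition and lower numbers for stronger inhibition), compound 1 `COc1ccc(C2OC(c3ccc4ccccc4c3)=NN2C(C)=O)cc1` gives 3.6 ug/mL, compound 2 `CC(=O)N1N=C(c2ccc3ccccc3c2)OC1c1ccc(Br)cc1` gives 2.08 ug/mL and compound 3 `CC(=O)N1N=C(c2ccc3ccccc3c2)OC1c1cccc(F)c1` gives 1.86 ug/mL. Compound 3 therefore stands within the scatter of both others. Compound 4 `CC(=O)N1N=C(c2ccc3ccccc3c2)OC1c1ccccn1` carries pyridin-2-yl in place of 3-fluorophenyl on a saturated ring carbon. The steps bearing on this change are exchanges of the aromatic ring on that same carbon: a 1.1-fold lower number from compound 2 to compound 3 (0.05 log units; within the scatter) and a 1.9-fold lower number from compound 1 to compound 3 (0.29 log units; within the scatter). Both are small, as is a 1.7-fold lower number from compound 1 to compound 2 (0.24 log units; within the scatter). Among the measured compounds shown here, no measured compound has a hetero atom in that aromatic ring, so the data suggest no direction, and no shift beyond the scatter is expected. The estimated step is a 1.2-fold higher number from compound 3 to compound 4 (0.09 log units; within the scatter). For compound 4 the expected value is 2.3 ug/mL, with an estimated range of 1 ug/mL to 5.5 ug/mL.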

Compound 4, half-maximal inhibitory concentration: 5.26 ug/mL
Compound 4: middle estimate off by 2.3-fold (0.36 log units), on the low side, and the stated range covers the measured number.
By their numbers in this assay, from the lowest: compounds 3, 2, 1 and 4 (each within the scatter of the next, the first and the last beyond it).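

In this assay, among the compounds shown here, the aromatic ring on this saturated ring carbon proves sensitive to change, with pyridin-2-yl giving a 2.8-fold higher number from compound 3 to compound 4 (0.45 log units; beyond the scatter) and a 2.5-fold higher number from compound 2 to compound 4 (0.40 log units; beyond the scatter), the first steps beyond the scatter. The 4-methoxyphenyl compound does not separate from it, with a 1.5-fold higher number from compound 1 to compound 4 (0.16 log units; within the scatter) as the step. No measurement shown accounts for this shift.

Still open, on these data alone, is whether the place of the ring nitrogen matters, as pyridin-3-yl or pyridin-4-yl would show. Also open, as far as these compounds go, is how an amine or a carboxylic acid on that ring would behave.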